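Exchanging the terminal aryl group on the shared core

The source may hold more compounds than are shown below. What is called first, only, known or untested is meant among the compounds shown, and "the series" means these compounds.

For the measured compounds named here, in a functional assay on NCI-H322M cells (Homo sapiens) for inhibition, read by sulforhodamine B assay, with a stated time of 48 h, tested at 100 uM (on this read-out lower numbers stand for a stronger effect and higher numbers for a weaker effect at the one concentration tested), compound 3 `COc1cc(Cl)cc(-c2nn(-c3cccc(NC(=O)Nc4ccc(Cl)c(Cl)c4)c3)cc2-c2ccncc2)c1` gives 3%, the highest of the three numbers known so far. Compound 1 `COc1cc(Cl)cc(-c2nn(-c3cccc(NC(=O)Nc4ccc(Cl)c(C(F)(F)F)c4)c3)cc2-c2ccncc2)c1` gives -22%, the nearest to it, and compound 2 `COc1cc(Cl)cc(-c2nn(-c3cccc(NC(=O)Nc4cc(C(F)(F)F)cc(C(F)(F)F)c4)c3)cc2-c2ccncc2)c1` gives -78%, the furthest from it. Compound 4 `COc1cc(Cl)cc(-c2nn(-c3cccc(NC(=O)Nc4cccc(C(F)(F)F)c4)c3)cc2-c2ccncc2)c1` has not yet been measured; it differs from compound 3 by 3-(trifluoromethyl)phenyl in place of 3,4-dichlorophenyl on an amide-type nitrogen. Going by the values given here, the only measured step that bears on this is a number 25 percentage points higher from compound 1 to compound 3 (beyond the scatter), a modest rise when chloro replaced trifluoromethyl. Among the compounds with values here, compound 4 partly reverses that exchange while also losing one chlorine, for which no step is known. A step of a number 15 percentage points lower from compound 3 to compound 4 (beyond the scatter) is therefore expected, downward but uncertain. Compound 4 is estimated at -12%, within a range of -45% to 15%.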

Compound 4, a percentage reported as activity, at one concentration (the size of the read-out at that concentration, not a potency): -8%
For compound 4 the middle estimate is 4 percentage points below the measured one, and the stated range covers the measured number.
By their numbers in this assay, from the lowest: compound 2; then compound 1; then compound 4; then compound 3.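

In this assay, the new compound gives the first view of the terminal aryl group with a single substituent: a number 70 percentage points higher from compound 2 to compound 4 (beyond the scatter) when hydrogen replaces trifluoromethyl is a large step, whereas a number 14 percentage points higher from compound 1 to compound 4 (beyond the scatter) when hydrogen replaces chloro is a modest one. The exchange of 3,4-dichlorophenyl for 3-(trifluoromethyl)phenyl on the amide-type nitrogen, a number 11 percentage points lower from compound 3 to compound 4 (beyond the scatter), is also modest. Nothing available explains these steps. Going by these compounds, what an amine or a methoxy group in place of trifluoromethyl would do on this aryl group remains open.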